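The source may hold more compounds than are shown below. What is called first, only, known or untested is meant among the compounds shown, and "the series" means these compounds.

Compound 3, `CCc1ccc(C(=O)Nc2cccc(-c3oc4cc(-c5ccc(F)cc5)ccc4c(=O)c3O)c2)cc1`, gives 20600 nM in a functional assay on HepG2 cells (Homo sapiens) for antiproliferative activity, read by CCK-8 assay, with a stated time of 72 h (on this read-out lower numbers stand for stronger inhibition and higher numbers for weaker inhibition), the highest of the three numbers measured, though within the scatter of both compound 1, `Cc1ccccc1C(=O)Nc1cccc(-c2oc3cc(-c4ccc(F)cc4)ccc3c(=O)c2O)c1`, at 19400 nM, and compound 2, `Cc1cccc(C(=O)Nc2cccc(-c3oc4cc(-c5ccc(F)cc5)ccc4c(=O)c3O)c2)c1`, at 13500 nM. Compound 4, `CCCc1ccc(C(=O)Nc2cccc(-c3oc4cc(-c5ccc(F)cc5)ccc4c(=O)c3O)c2)cc1`, differs from compound 3 by methyl in place of hydrogen on a saturated chain carbon, two bonds along the chain from an aromatic carbon. Going by the values given here, no measured step varies a chain in this way; the nearest comparisons change the substituent pattern on the amide aryl ring, and all stay within the scatter: a 1.4-fold lower number from compound 1 to compound 2 (0.16 log units; within the scatter), a 1.1-fold higher number from compound 1 to compound 3 (0.03 log units; within the scatter), a 1.5-fold higher number from compound 2 to compound 3 (0.18 log units; within the scatter). Because compound 3 gives 20600 nM and the three steps around it show no movement beyond the scatter, compound 4 is expected to stay close to compound 3, and the step of a 1.0-fold higher number from compound 3 to compound 4 (0.01 log units; within the scatter) is estimated to fall within the scatter. Compound 4 is therefore expected to give about 21000 nM, with a range from 8000 nM to 55000 nM.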

Compound 4, half-maximal inhibitory concentration: 51500 nM
Compound 4: middle estimate off by 2.5-fold (0.39 log units), on the low side; the range from low to high includes it.
By their numbers in this assay, from the lowest: compounds 2, 1 and 3 (each within the scatter of the next); then compound 4.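

In this assay, going by these compounds alone, one added methyl, turning 4-ethylphenyl into 4-propylphenyl, gives the first single change to move the number beyond the scatter, toward weaker inhibition: a 2.5-fold higher number from compound 3 to compound 4 (0.40 log units; beyond the scatter). The same separation appears against the two methylphenyl amides, a 3.8-fold higher number from compound 2 to compound 4 (0.58 log units; beyond the scatter) and a 2.7-fold higher number from compound 1 to compound 4 (0.42 log units; beyond the scatter), whereas the three earlier numbers all lay within the scatter of one another. Nothing available accounts for this loss.

With only ethyl and propyl at this position, no trend along the chain can be claimed. As far as these compounds go, whether a butyl chain would weaken inhibition further, or how an amine or a carboxylic acid in place of the propyl group would read, stays open.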